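A few compounds are considered here, and "the series" means these few. Any claim that something is new, unique, unknown or untested is made for them only; others in the source may bear on it.

Among the compounds with values here, compound 2 `CCCCCCCc1ccc(NC(=O)N[C@@H](C)c2ccccc2)cc1` gives 99% in an ADME assay on the whole organism with Oryza sativa as the target, tested at 1 uM (on this read-out lower numbers stand for a stronger effect and higher numbers for a weaker effect at the one concentration tested), the higher of the two numbers so far, though only by a step within the scatter: compound 1 `CCc1ccc(NC(=O)N[C@@H](C)c2ccccc2)cc1` gives 95% in this assay, and the step of a number 4 percentage points higher from compound 1 to compound 2 (within the scatter) is within the scatter. Compound 3 `C[C@H](NC(=O)Nc1ccc(F)cc1)c1ccccc1` differs from compound 2 by fluoro in place of heptyl on an aromatic carbon. Within the data shown here, only that one step bears on the change, and it varied the chain without removing it; both measured numbers lie close to the top of the scale. The expected step of a number 4 percentage points lower from compound 2 to compound 3 (within the scatter) is therefore none beyond the scatter. Compound 3 is expected to give 95%, with a range from 85% to 100%.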

Compound 3, a percentage reported as activity, at one concentration (the size of the read-out at that concentration, not a potency): 97%
The estimate for compound 3 lay 2 percentage points below the measured number; the range from low to high includes it.
By their numbers in this assay, from the lowest: compounds 1, 3 and 2 (each within the scatter of the next).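

Fluoro in place of heptyl gives a number 2 percentage points lower from compound 2 to compound 3 (within the scatter) in this assay, and fluoro in place of ethyl gives a number 2 percentage points higher from compound 1 to compound 3 (within the scatter). On this aromatic carbon, para to a large group, a single fluorine therefore reads the same as either carbon chain, and no separation appears among the three groups. No measured evidence bears on this result.

Going by these compounds, whether an amine or a carboxylic acid on this carbon would give a number clearly lower remains open. The compounds shown also leave open whether changes elsewhere on the shared core affect the read-out.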